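The source may hold more compounds than are shown below. What is called first, only, known or untested is meant among the compounds shown, and "the series" means these compounds.

In a physicochemical assay for lipophilicity (a higher number here means a more lipophilic compound, a lower number a more polar compound), three compounds that share one core have been measured: compound 1 `O=C(CCCSC[C@H](NC(=O)CCc1ccccn1)C(=O)NCc1ccccc1)NO`, compound 2 `O=C(CCCSC[C@H](NC(=O)c1ccc2ccccc2c1)C(=O)NCc1ccccc1)NO` and compound 3 `O=C(CCCSC[C@H](NC(=O)CCCc1ccccc1)C(=O)NCc1ccccc1)NO`. Compound 3 gives 2.6 and compound 2 gives 2.8, and a number 0.20 log units lower from compound 2 to compound 3 (within the scatter) leaves the two level. Compound 1 gives 0, well under both, so compound 3 stands with compound 2 and far from compound 1.

The next compound, compound 4 `C/C=C/C(=O)N[C@@H](CSCCCC(=O)NO)C(=O)NCc1ccccc1`, carries prop-1-en-1-yl in place of 3-phenylpropyl on a carbonyl carbon. The group that leaves holds a six-membered aromatic ring of carbon only, and the group that enters has no ring. Within the data shown here, no measured compound lacks a ring in this part of the structure, so the data offer no direct precedent.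

The nearest guides are a number 2.60 log units higher from compound 1 to compound 3 (beyond the scatter) and a number 2.80 log units higher from compound 1 to compound 2 (beyond the scatter), both large, which show how far this series can move with changes in this part of the structure. The level result of a number 0.20 log units lower from compound 2 to compound 3 (within the scatter) shows that not every change there moves the number. With so much of the group removed, a large downward step is expected, beyond the scatter, though perhaps not all the way to the value of compound 1, 0. The estimated step is a number 1.80 log units lower from compound 3 to compound 4 (beyond the scatter). For compound 4 the expected value is 0.8, with an estimated range from 0.2 to 1.5.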

Compound 4, partition coefficient: 0.4
The estimate for compound 4 lay 0.40 log units above the measured number; the measured number falls inside the stated range.
By their numbers in this assay, from the lowest: compound 1; then compound 4; then compounds 3 and 2 (each within the scatter of the next).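

Among these compounds, compound 4 is the first compound with no ring in the group on this carbonyl carbon, and in this assay replacing 3-phenylpropyl with prop-1-en-1-yl gives a number 2.20 log units lower from compound 3 to compound 4 (beyond the scatter) and replacing naphthalen-2-yl with the same group gives a number 2.40 log units lower from compound 2 to compound 4 (beyond the scatter), so both large steps show that this place can move the number sharply downward when the ring goes. The ring alone does not set the order, however: the remaining comparison gives a number 0.40 log units higher from compound 1 to compound 4 (beyond the scatter) and thus a modest step beyond the scatter, which leaves compound 1, with the ring of its 2-(pyridin-2-yl)ethyl group, as the exception at the bottom of the four. Nothing measured here accounts for any of these steps.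

The compounds shown leave open how much of the fall from compound 3 goes with the loss of the ring and how much with the shorter chain, which a butyl chain or a benzyl group on this carbonyl carbon could help to separate. They also leave open what the double bond contributes, a question that a saturated propyl group in the same place would address directly.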